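The source may report more compounds than this note shows. Statements on the series, on what has been measured and on what is new or still open speak of the compounds shown alone.

Working notes on the series. Compound 1 (`CCOCc1c(C)coc1-c1ccc2c(c1OC)CCCC2(C)C`) stands at 16.5 uM in a functional assay on KBVIN cells (Homo sapiens) for cytotoxicity, read by sulforhodamine B assay, with a stated time of 3 days (a lower number here means that less compound is needed, a higher number that more compound is needed for the effect), and lies within the scatter of both other measured compounds. Compound 3 (`Cc1coc(-c2ccc3c(c2O)CCCC3(C)C)c1CO`) reads 19.9 uM and compound 2 (`CCc1cccc2c(O)c(-c3occ(C)c3C(=O)O)ccc12`) reads 23.6 uM on the same read-out, so compound 1 is not separated from either.

Compound 4 (`COCc1c(C)coc1-c1ccc2c(c1OC)CCCC2(C)C`) is still unmeasured. Its difference from compound 1 is hydrogen in place of methyl on a saturated chain carbon bound to an oxygen on a saturated carbon, which changes ethoxymethyl to methoxymethyl.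

Among the measured compounds shown here, no measured pair differs in one place only, so this change has no direct precedent. Compound 3 at 19.9 uM and compound 2 at 23.6 uM differ from compound 1 by more than this change and still fall within the scatter, so no step beyond the scatter is expected in this assay here. The expected step is a 1.1-fold higher number from compound 1 to compound 4 (0.04 log units; within the scatter) and it stays within the scatter. The estimated value for compound 4 is 18 uM (expected range 10 uM to 32 uM).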

Compound 4, concentration for half-maximal effect: 20.1 uM
Beside the measured number, compound 4's estimate is 1.1-fold (0.05 log units) below it, and the stated range covers the measured number.
By their numbers in this assay, from the lowest: compounds 1, 3, 4 and 2 (each within the scatter of the next).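

The pair of compound 1 and compound 4 gives the series its first reading of a change in one place: in this assay, hydrogen in place of methyl on a saturated chain carbon bound to an oxygen on a saturated carbon gives a 1.2-fold higher number from compound 1 to compound 4 (0.09 log units; within the scatter) and so does not separate the two compounds. Among the compounds shown here, on the core of compound 1, ethoxymethyl and methoxymethyl therefore cannot be told apart on this read-out, which is a direct result where the earlier compounds offered only indirect comparison. No measurement on hand bears on why the step is this size.

Still open, from the compounds shown here alone, is whether a longer chain such as butoxymethyl, or an amine at this place, would also stay within the scatter. A single pair also leaves open whether this reading holds for any other change at this position.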